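From methoxy to ethoxy on a shared core

The source may report more compounds than this note shows. Statements on the series, on what has been measured and on what is new or still open speak of the compounds shown alone.

Going by the values given here, only two compounds with this core have numbers so far. In a physicochemical assay, with a stated time of 30 min (on this read-out higher numbers stand for weaker inhibition and lower numbers for stronger inhibition), compound 1 (`COc1cc2c(cc1OC)C(=O)C(C(=O)Nc1ccccc1C)C2`) gives 43.7 ug/mL as its value, and compound 2 (`COc1ccccc1NC(=O)C1Cc2cc(OC)c(OC)cc2C1=O`) gives 45.8 ug/mL as its value. Among the compounds with values here, compound 2 therefore stands level with the only other compound measured, since the two numbers lie within the scatter of each other.

Compound 3 (`CCOc1ccccc1NC(=O)C1Cc2cc(OC)c(OC)cc2C1=O`) has not been measured. It differs from compound 2 by methyl in place of hydrogen on a saturated chain carbon bound to an oxygen on an aromatic ring as a single change: methyl in place of hydrogen on a saturated chain carbon bound to an oxygen on an aromatic ring, which turns methoxy into ethoxy.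

Just one measured step bears on this. Going from methyl to methoxy on an aromatic carbon gave a 1.0-fold higher number from compound 1 to compound 2 (0.02 log units; within the scatter) as its size, so that neighbouring swap moved the number no further than the scatter. It is a different change and thin evidence, but it points to no direction. An estimated step of a 1.0-fold lower number from compound 2 to compound 3 (0.01 log units; within the scatter) is therefore expected, meaning none beyond the scatter. For compound 3 the expected value is 45 ug/mL within an estimated range from 24 ug/mL to 85 ug/mL until a measurement arrives.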

Compound 3, half-maximal inhibitory concentration: 63.7 ug/mL
Estimate against measurement, compound 3: 1.4-fold (0.15 log units) below; the measured number falls inside the stated range.
By their numbers in this assay, from the lowest: compounds 1, 2 and 3 (each within the scatter of the next).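

Turning methoxy into ethoxy, by putting a methyl on a saturated chain carbon bound to an oxygen on an aromatic ring, gives a 1.4-fold higher number from compound 2 to compound 3 (0.14 log units; within the scatter) in this assay, so extending the group outward by this one carbon causes no shift beyond the scatter. The wider swap gives a 1.5-fold higher number from compound 1 to compound 3 (0.16 log units; within the scatter), which means that methyl, methoxy and ethoxy all read level here, whereas the earlier pair covered only the first two of these groups. No measurement available here accounts for how closely these numbers sit together.

As far as these compounds go, the three compounds span only a narrow family of small groups, so it remains open whether a longer chain such as propoxy or butoxy would also stay level, or whether an amine or a carboxylic acid on the same aromatic carbon would move the number beyond the scatter. From the compounds shown here alone, it also remains open whether any replacement at this place can shift the number in either direction.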